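Changing the five-membered ring at the piperazine-bearing position

The compounds below may be only part of what the source reports. "The series", "measured", "known", "first", "only" and "open" are said of these compounds alone.

Measured compounds:
compound 1 `Cn1cnc(CN2CCN(c3cccc4[nH]c(-c5ccc(C(C)(C)C)cc5)nc34)CC2)c1` with 33 nM
compound 2 `Cc1nc(CN2CCN(c3cccc4[nH]c(-c5ccc(C(C)(C)C)cc5)nc34)CC2)c[nH]1` with 7.5 nM
compound 3 `Cc1nc(C)c(CN2CCN(c3cccc4[nH]c(-c5ccc(C(C)(C)C)cc5)nc34)CC2)s1` with 27 nM

In an assay on isolated protein for displacement of a labelled ligand from Gonadotropin-releasing hormone receptor (Homo sapiens) (on this read-out lower numbers stand for stronger inhibition and higher numbers for weaker inhibition), compound 1 gives the highest number of the three: compound 3 sits closest, at a 1.2-fold lower number from compound 1 to compound 3 (0.09 log units; within the scatter), while compound 2 lies furthest, at a 4.4-fold lower number from compound 1 to compound 2 (0.64 log units; beyond the scatter). Between compound 2 and compound 3 the step is a 3.6-fold higher number from compound 2 to compound 3 (0.56 log units; beyond the scatter).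

Compound 4 `CCc1nc(C)c(CN2CCN(c3cccc4[nH]c(-c5ccc(C(C)(C)C)cc5)nc34)CC2)s1` is not yet measured. It differs from compound 1 in one place: 2-ethyl-4-methyl-1,3-thiazol-5-yl in place of 1-methyl-1H-imidazol-4-yl on a saturated chain carbon bound to an amine nitrogen in a ring

For the measured compounds named here, the step that bears most directly on this change is the one from compound 1 to compound 3, which exchanged the same 1-methyl-1H-imidazol-4-yl group for the closely related 2,4-dimethyl-1,3-thiazol-5-yl group and stayed within the scatter. The step to compound 2 shows that a different replacement at this place can move the number, but compound 4 carries the thiazole-type group, so no step beyond the scatter is expected in this assay.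

For compound 4 the estimated step is a 1.3-fold lower number from compound 1 to compound 4 (0.12 log units; within the scatter), giving an expected value of 25 nM, with a range of 8 nM to 75 nM.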

Compound 4, half-maximal inhibitory concentration: 20 nM
For compound 4 the middle estimate is 1.3-fold (0.10 log units) above the measured one; low and high end bracket the measured number.
By their numbers in this assay, from the lowest: compound 2; then compounds 4, 3 and 1 (each within the scatter of the next).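

In this assay, adding one methyl to the chain on the thiazole, which turns the 2,4-dimethyl-1,3-thiazol-5-yl group into the 2-ethyl-4-methyl-1,3-thiazol-5-yl group, leaves the number within the scatter (a 1.4-fold lower number from compound 3 to compound 4 (0.13 log units; within the scatter)). The larger group also stays within the scatter of the original 1-methyl-1H-imidazol-4-yl group (a 1.7-fold lower number from compound 1 to compound 4 (0.22 log units; within the scatter)), so the change in ring and the growth of the chain together do not clearly move the number. The 2-methyl-1H-imidazol-4-yl group of compound 2 remains apart, now from this second thiazole as well (a 2.7-fold higher number from compound 2 to compound 4 (0.43 log units; beyond the scatter)).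

No measurement here explains why these steps are small or large. On these data alone, it also remains open whether a longer chain such as propyl, or an amine or a carboxylic acid, would be accepted in place of the ethyl group on the thiazole.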